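Restoring a ring on the nitrogen-bound methyl of compound 2

The compounds below may be only part of what the source reports. "The series", "measured", "known", "first", "only" and "open" are said of these compounds alone.

Compound 2 `CN1CCC[C@H](OCc2cc(Cl)cc(Cl)c2)[C@@H]1c1ccccc1` carries a plain methyl on the ring nitrogen and is the weakest-defined point in the set: in an assay on isolated protein for activation of cGMP-dependent protein kinase 1 (Homo sapiens), read by ADP-Glo, with stated times of 120 min and 40 min (a higher number here means that more compound is needed for the effect, a lower number that less compound is needed), compound 2 gives > 200000 nM, which is a limit of the assay and not a number. Compound 1 `Cn1cc(CN2CCC[C@H](OCc3cc(Cl)cc(Cl)c3)[C@@H]2c2ccccc2)cn1` gives 110000 nM in this assay, and an at least 1.8-fold higher number from compound 1 to compound 2 (0.25 log units; that floor lies within the scatter) sets only a floor on that step because of the limit of > 200000 nM in this assay, at which 1 of the 3 values shown sits. Going by the values given here, compound 3 `OC[C@@H](O[C@H]1CCCN(Cc2cccc3nonc23)[C@H]1c1ccccc1)c1cc(Cl)cc(Cl)c1`, built on a different pattern, gives 8000 nM; no single-change step links it to compound 2. Compound 4 `Clc1cc(Cl)cc(CO[C@H]2CCCN(Cc3ncc[nH]3)[C@H]2c2ccccc2)c1` differs from compound 2 by 1H-imidazol-2-yl in place of hydrogen on a saturated chain carbon bound to an amine nitrogen in a ring. Among the compounds with values here, the one step that bears on it runs the other way, hydrogen replacing 1-methyl-1H-pyrazol-4-yl, and it raised the number by an amount the data can only bound. The return of a five-membered aromatic ring with 2 hetero atoms is therefore expected to lower the number, giving an at least 2.0-fold lower number from compound 2 to compound 4 (0.30 log units; that floor lies within the scatter) as the estimated step, its size left uncertain. Compound 4 is thus expected to give 100000 nM, between 30000 nM and 200000 nM.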

Compound 4, half-maximal effective concentration: 47000 nM
For compound 4 the middle estimate is 2.1-fold (0.33 log units) above the measured one, within the range that was stated.
By their numbers in this assay, from the lowest: compound 3; then compound 4; then compound 1. At a limit, above all of these: compound 2.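

With 1H-imidazol-2-yl in place of hydrogen on a saturated chain carbon bound to an amine nitrogen in a ring, this assay shows an at least 4.2-fold lower number from compound 2 to compound 4 (0.62 log units; beyond the scatter), so a ring at this place now gives a change beyond the scatter, which the earlier step could not show. For compound 2 the reading is a limit and not a number, so this step remains a floor: the limit of > 200000 nM in this assay, at which 1 of the 4 values shown sits. The choice of ring also matters, as exchanging 1-methyl-1H-pyrazol-4-yl for 1H-imidazol-2-yl gives a 2.3-fold lower number from compound 1 to compound 4 (0.37 log units; beyond the scatter).

That exchange alters the ring in more than one respect, so the compounds shown leave open which difference carries the change. They also leave open whether 1-methyl-1H-imidazol-2-yl or a six-membered ring such as pyridin-2-yl would serve at this place.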